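Adding a Third Methoxy Group: Expected Effect on Cytotoxicity

The source may report more compounds than this note shows. Statements on the series, on what has been measured and on what is new or still open speak of the compounds shown alone.

Of the compounds shown here, three sharing one core have been tested in a functional assay on DU-145 cells (Homo sapiens) for cytotoxicity, read by MTT assay, with a stated time of 48 h; on this read-out higher numbers stand for weaker inhibition and lower numbers for stronger inhibition. Compound 1 `COc1cc(-c2cc(C(=O)Nc3nc4ccc(Cl)cc4s3)nc3cc(-c4ccccc4)nn23)cc(OC)c1OC` gives 38900 nM. Compound 2 `COc1ccc2nc(NC(=O)c3cc(-c4ccc(F)cc4)n4nc(-c5ccccc5)cc4n3)sc2c1` gives 15400 nM. Compound 3 `COc1ccc2nc(NC(=O)c3cc(-c4ccc(OC)c(OC)c4)n4nc(-c5ccccc5)cc4n3)sc2c1` gives 14000 nM, the lowest of the three numbers; its gap to compound 2 is within the scatter, while compound 1 sits beyond the scatter with a higher number. For the measured compounds named here, the only single change measured so far, a 1.1-fold lower number from compound 2 to compound 3 (0.04 log units; within the scatter), shows that swapping one aryl group for another at that position hardly moved the read-out.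

Compound 4 `COc1ccc2nc(NC(=O)c3cc(-c4cc(OC)c(OC)c(OC)c4)n4nc(-c5ccccc5)cc4n3)sc2c1` is compound 3 with one more change: methoxy in place of hydrogen on an aromatic carbon. Going by the values given here, no measured pair tests exactly this addition. Compound 1 also carries the 3,4,5-trimethoxyphenyl group but differs from compound 4 elsewhere, so its value is only a loose pointer; it does suggest that the trimethoxyphenyl group gives no strong gain here. Since the earlier aryl swap stayed within the scatter, the step from compound 3 to compound 4 is expected to be small, a 1.3-fold higher number from compound 3 to compound 4 (0.11 log units; within the scatter), leaning toward a slightly higher number. Compound 4 is therefore estimated at 18000 nM in this assay, with a range from 8000 nM to 40000 nM.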

Compound 4, half-maximal inhibitory concentration: 3980 nM
Beside the measured number, compound 4's estimate is 4.5-fold (0.66 log units) above it, and the stated range ends above it.
By their numbers in this assay, from the lowest: compound 4; then compounds 3 and 2 (each within the scatter of the next); then compound 1.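

In this assay, for the compounds shown here, adding the third methoxy group is the first change at this aryl position to move the read-out clearly: a 3.5-fold lower number from compound 3 to compound 4 (0.55 log units; beyond the scatter) lies beyond the scatter, while the earlier swap, a 1.1-fold lower number from compound 2 to compound 3 (0.04 log units; within the scatter), did not. Replacing 4-fluorophenyl with the full 3,4,5-trimethoxyphenyl group gives a 3.9-fold lower number from compound 2 to compound 4 (0.59 log units; beyond the scatter), so among compounds 2, 3 and 4, the aryl change becomes visible only when all three methoxy groups are present. The 3,4,5-trimethoxyphenyl group is not enough by itself, since compound 1 carries it too; the second site on the core also matters, with methoxy in place of chloro on an aromatic carbon giving a 9.8-fold lower number from compound 1 to compound 4 (0.99 log units; beyond the scatter) in the same assay. Nothing available here explains why either change shifts the read-out.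

On these data alone, it remains open whether a hydroxyl group or an amine on this aromatic carbon would give a similar shift to the added methoxy group. A longer chain such as ethoxy is also untested among the compounds shown, as is any replacement for the methoxy group at the second site.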